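The compounds below may be only part of what the source reports. "The series", "measured", "known", "first", "only" and "open" are said of these compounds alone.

Values measured in an ADME assay on the whole organism (strain Sprague-Dawley) for pharmacokinetics, with Rattus norvegicus as the target, using cassette dosing, at a dose of 1 mg/kg by the oral route; on this read-out higher numbers stand for higher oral bioavailability and lower numbers for lower oral bioavailability:
- compound 1 `O=C(C[C@]1(O)CC[C@@H](Cc2ccc(OC(F)(F)F)cc2)CC1)Nc1ccc2[nH]c(=O)oc2c1`: 53.4%
- compound 2 `O=c1ccc(-c2cc(C[C@]3(O)CC[C@@H](Cc4ccc(Cl)cc4)CC3)no2)c[nH]1`: 37.2%
- compound 3 `O[C@]1(Cc2cc(-c3cn[nH]c3)on2)CC[C@H](Cc2ccc(Cl)cc2)CC1`: 72.8%
- compound 4 `COc1ccc(C[C@H]2CC[C@](O)(Cc3cc(-c4cn[nH]c4)on3)CC2)cc1`: not yet measured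

Compound 3 stands highest of the three in this assay, and its gaps to compound 1 and to compound 2 both lie beyond the scatter. Compound 4 differs from compound 3 in one place: methoxy in place of chloro on an aromatic carbon. This is methoxy in place of chloro on an aromatic carbon, para to a large group, so 4-chlorobenzyl becomes 4-methoxybenzyl.

Among the measured compounds shown here, only one measured step is available, a number 35.6 percentage points higher from compound 2 to compound 3 (beyond the scatter). It is large, but it exchanges a different group and leaves the chloro untouched, so it gives no direct guide to size or direction here. For the measured compounds named here, no measured pair tests chloro against methoxy. The default expectation is therefore a moderate step with wide uncertainty, one that may not clear the scatter. A slight lean downward is expected, resting only on compound 3 holding the highest value, 72.8%, among just three compounds. The expected change is a number 9.8 percentage points lower from compound 3 to compound 4 (within the scatter). For compound 4 the estimated value is 63%, with an expected range of 40% to 82%.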

Compound 4, oral bioavailability: 23.7%
Estimate against measurement, compound 4: 39.3 percentage points above, and the stated range ends above it.
By their numbers in this assay, from the lowest: compound 4; then compound 2; then compound 1; then compound 3.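

The exchange of 4-chlorobenzyl for 4-methoxybenzyl is the only pair shown that tests this position, and in this assay it gives a number 49.1 percentage points lower from compound 3 to compound 4 (beyond the scatter), so the group on this aromatic carbon, para to a large group, strongly affects this read-out within the series. The earlier a number 35.6 percentage points higher from compound 2 to compound 3 (beyond the scatter) came from a change at a different place, so a large step from a single exchange has now been seen at two separate places in the molecule, in opposite directions. No measurement is available that bears on the reason for the drop from chloro to methoxy.

With a single pair, the compounds shown cannot tell whether the step reflects the loss of chloro, the arrival of methoxy or both, and fluoro, methyl or nitrile at the same place would begin to separate these readings. Nor do they show whether methoxy in place of chloro gives a step of like size and direction on the core of compound 2, which carries the same 4-chlorobenzyl group.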